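Fluorophenyl for methylphenyl on a piperazine amide

This account rests on a few compounds, and the source may have more. Where it says the series, first, only, none or still open, it means among the compounds named here.

Compound 1 `CC#CC(CC(=O)O)c1ccc(OCc2ccc(C(=O)N3CCN(c4ccccc4)CC3)s2)cc1` gives 72 nM in a functional assay on HEK293 cells for agonist activity at Free fatty acid receptor 1 (Homo sapiens), read by fluorescence and calcium flux; on this read-out lower numbers stand for an effect already at smaller amounts and higher numbers for an effect only at larger amounts of compound.
Compound 2 `CC#CC(CC(=O)O)c1ccc(OCc2ccc(C(=O)N3CCN(c4ccccn4)CC3)s2)cc1` gives 138 nM in this assay.
Compound 3 `CC#CC(CC(=O)O)c1ccc(OCc2ccc(C(=O)N3CCN(c4ccc(C)cc4)CC3)s2)cc1` gives 211 nM in this assay.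

Compound 3 stands at the highest of the three numbers. Its nearest neighbour is compound 2, separated by a 1.5-fold higher number from compound 2 to compound 3 (0.18 log units; within the scatter), which is within the scatter; the furthest is compound 1, separated by a 2.9-fold higher number from compound 1 to compound 3 (0.47 log units; beyond the scatter), which lies beyond the scatter. Compound 4 `CC#CC(CC(=O)O)c1ccc(OCc2ccc(C(=O)N3CCN(c4ccccc4F)CC3)s2)cc1` differs from compound 3 in one place: 2-fluorophenyl in place of 4-methylphenyl on an amine nitrogen in a ring. Among the compounds with values here, two measured steps bear on this change. The step of a 2.9-fold higher number from compound 1 to compound 3 (0.47 log units; beyond the scatter) shows the effect of putting a methyl on that aromatic ring in place of hydrogen, and the step of a 1.9-fold higher number from compound 1 to compound 2 (0.28 log units; within the scatter) shows that exchanging the whole aryl group on the ring nitrogen moved the number only within the scatter. Compound 4 keeps a six-membered aromatic ring of carbon only on the ring nitrogen but no longer carries the methyl, so its number is expected to fall back toward that of compound 1. In this assay compound 4 is therefore estimated at 110 nM, with a range of 50 nM to 250 nM. This estimate amounts to an expected 1.9-fold lower number from compound 3 to compound 4 (0.28 log units; within the scatter), a modest lowering rather than a large shift.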

Compound 4, half-maximal effective concentration: 113 nM
The estimate for compound 4 lay 1.0-fold (0.01 log units) below the measured number, within the range that was stated.
By their numbers in this assay, from the lowest: compounds 1, 4, 2 and 3 (each within the scatter of the next, the first and the last beyond it).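

The added fluoro stays within the scatter of compound 1 (a 1.6-fold higher number from compound 1 to compound 4 (0.20 log units; within the scatter)), whereas methyl in place of hydrogen went beyond it (a 2.9-fold higher number from compound 1 to compound 3 (0.47 log units; beyond the scatter)), so in this assay the aryl group on the amine nitrogen can now be seen to carry a substituent without a step beyond the scatter. The exchange itself does not separate 2-fluorophenyl from 4-methylphenyl (a 1.9-fold lower number from compound 3 to compound 4 (0.27 log units; within the scatter)), and 2-fluorophenyl is not separated from pyridin-2-yl either (a 1.2-fold lower number from compound 2 to compound 4 (0.09 log units; within the scatter)), which leaves compound 4 within the scatter of all three other compounds and the gap between compound 1 and compound 3 as the only one beyond it. No evidence is at hand that would account for these numbers.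

The names 2-fluorophenyl and 4-methylphenyl differ in both the group and its place on the ring, so compound 3 and compound 4 cannot tell these two changes apart. Compounds bearing 4-fluorophenyl or 2-methylphenyl would change only one of the two, and the compounds shown leave open how either would read.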